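Aryl swap on compound 2 and stability in microsomes

The source may report more compounds than this note shows. Statements on the series, on what has been measured and on what is new or still open speak of the compounds shown alone.

In an ADME assay on microsomes from liver (Homo sapiens) for metabolic stability, read by LC-MS, with NADPH named in the record, with a stated time of 60 min, tested at 1 uM, in the absence of a further agent (a higher number here means that more of the compound is left, a lower number that less of the compound is left), two compounds have been run so far, compound 1 (`COc1ccc(-c2c(C)oc3c(N4CC[C@@H](NC(C)=O)C4)cc(C)nc23)cc1OC`) and compound 2 (`CC(=O)N[C@@H]1CCN(c2cc(C)nn3c(-c4ccc(C(F)(F)F)cc4)c(C)nc23)C1`). Compound 1 gives > 95% as a limit of the assay. Compound 2 gives > 95% as a limit too, so its standing is known only as that limit and not as a number. Compound 3 (`COc1ccc(-c2c(C)nc3c(N4CC[C@@H](NC(C)=O)C4)cc(C)nn23)cn1`) carries 6-methoxypyridin-3-yl in place of 4-(trifluoromethyl)phenyl on an aromatic carbon. Among the measured compounds shown here, no measured step covers this change. In this assay only a small downward shift, perhaps none beyond the scatter, is expected (a number at least 5 percentage points lower from compound 2 to compound 3 (that floor lies within the scatter)). Compound 3 is estimated at 90% with 72% to 100% as the expected range.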

Compound 3, percent of the compound remaining: > 95%
Compound 3 was reported as a limit; the forecaster's own chance of this, stated with the estimate: 45%; middle value at least 5 percentage points away from the limit.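

Among the compounds shown here, no step from compound 2 to compound 3 can be read in this assay, because both values stop at one limit: the limit of > 95% in this assay, at which 3 of the 3 values shown sit. The compounds shown leave open whether 6-methoxypyridin-3-yl in place of 4-(trifluoromethyl)phenyl changes the percent of compound remaining at all.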